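Swapping the Sulfonyl Substituent: Expected Microsomal Stability

The source may report more compounds than this note shows. Statements on the series, on what has been measured and on what is new or still open speak of the compounds shown alone.

Measured in an ADME assay on microsomes from liver (Rattus norvegicus) for metabolic stability, with a stated time of 10 min; a higher number here means that more of the compound is left, a lower number that less of the compound is left:
compound 1 `CC(C)OC(=O)NCCS(=O)(=O)NC(=O)c1ccc(Nc2nc(NC3(c4ccc(Cl)cc4)CC3)nc(OCC(F)(F)F)n2)cc1` gives 73%
compound 2 `CC(C)(C)NC(=O)NCCS(=O)(=O)NC(=O)c1ccc(Nc2nc(NC3(c4ccc(Cl)cc4)CC3)nc(OCC(F)(F)F)n2)cc1` gives 93%
compound 3 `CC(C)C(=O)NCCS(=O)(=O)NC(=O)c1ccc(Nc2nc(NC3(c4ccc(Cl)cc4)CC3)nc(OCC(F)(F)F)n2)cc1` gives 84%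

Compound 3 stands second highest of the three numbers in this assay. Its nearest neighbour is compound 2, with a number 9 percentage points lower from compound 2 to compound 3 (within the scatter), and its furthest is compound 1, with a number 11 percentage points higher from compound 1 to compound 3 (beyond the scatter). The steps from compound 1, namely a number 20 percentage points higher from compound 1 to compound 2 (beyond the scatter) and a number 11 percentage points higher from compound 1 to compound 3 (beyond the scatter), both concern the group on the carbonyl carbon of the ethyl chain and both raise the number modestly.

Compound 4 `CN(C)S(=O)(=O)NC(=O)c1ccc(Nc2nc(NC3(c4ccc(Cl)cc4)CC3)nc(OCC(F)(F)F)n2)cc1` differs from compound 3 in another way: dimethylamino in place of 2-((isopropylcarbonyl)amino)ethyl on a sulfonyl sulfur. Within the data shown here, none of the measured steps makes this change; they only vary the cap on the chain that now leaves entirely. All three measured compounds, however, give high numbers in this assay, so compound 4 is expected to remain in that high region, and the expected step is no change at the digits printed from compound 3 to compound 4 (within the scatter), that is, no change beyond the scatter. For compound 4 the estimate in this assay is 84%, with a range from 65% to 98%.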

Compound 4, percent of the compound remaining: 76%
Beside the measured number, compound 4's estimate is 8 percentage points above it; measured number inside the range.
By their numbers in this assay, from the lowest: compounds 1, 4, 3 and 2 (each within the scatter of the next, the first and the last beyond it).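

In this assay, dimethylamino in place of the whole 2-((isopropylcarbonyl)amino)ethyl chain on the sulfonyl sulfur gives a number 8 percentage points lower from compound 3 to compound 4 (within the scatter), so this position accepts the loss of that chain without a step beyond the scatter. The same replacement gives a number 3 percentage points higher from compound 1 to compound 4 (within the scatter) for the 2-((isopropoxycarbonyl)amino)ethyl chain but a number 17 percentage points lower from compound 2 to compound 4 (beyond the scatter) for the 2-(((tert-butyl)carbamoyl)amino)ethyl chain, so among these compounds only the last chain stands apart from dimethylamino. Nothing available to this account explains these steps.

The compounds shown leave open how a cyclic amine such as morpholine, or a plain methyl, would read on the sulfonyl sulfur in this assay. They also leave open whether a longer chain carrying the tert-butyl carbamoyl group would keep the number of compound 2 93% in that assay.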